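Adding a Single Fluorine to a Pyridine Amide Series

The source may hold more compounds than are shown below. What is called first, only, known or untested is meant among the compounds shown, and "the series" means these compounds.

Compound 1 `O=C(Nc1ccc(Oc2ccnc3[nH]ccc23)cc1)c1ccc(-c2ccc(F)cc2F)cn1` joins an amide-linked aryl piece to the shared core. In a functional assay on A549 cells (Homo sapiens) for cytotoxicity, read by MTT assay, with a stated time of 72 h (a higher number here means a weaker inhibitor, a lower number a stronger inhibitor), compound 1 gives only a limit of the assay, > 10000 nM. Compound 2 `CCc1ccc(-c2ccc(C(=O)Nc3ccc(Oc4ccnc5[nH]ccc45)cc3)nc2)cc1` carries 4-ethylphenyl in place of 2,4-difluorophenyl on an aromatic carbon. In this assay compound 2 likewise gives only a limit, > 10000 nM. The step that the two limits leave unreadable from compound 1 to compound 2 therefore cannot be read. Both known values sit at the limit of > 10000 nM in this assay, at which 2 of the 2 values shown sit.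

Compound 3 `O=C(Nc1ccc(Oc2ccnc3[nH]ccc23)c(F)c1)c1ccc(-c2ccc(F)cc2F)cn1` differs from compound 1 by fluoro in place of hydrogen on an aromatic carbon. For the measured compounds named here, no measured step touches this change, and the one measured step is unreadable, so the known numbers offer no direction. From compound 1 to compound 3 the expected step is a step that the limit leaves unreadable from compound 1 to compound 3, nothing beyond the scatter. Compound 3 is estimated at about 15000 nM in this assay, most probably again as a limit, with a range from 4000 nM to 60000 nM.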

Compound 3, half-maximal inhibitory concentration: 3100 nM
For compound 3 the middle estimate is 4.8-fold (0.68 log units) above the measured one, and the stated range ends above it.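

A single fluoro in place of hydrogen, on an aromatic carbon of a six-membered aromatic ring of carbon only, ortho to a large group and meta to a large group, is enough for a readable change in this assay, namely an at least 3.2-fold lower number from compound 1 to compound 3 (0.50 log units; beyond the scatter). Among the compounds shown, this is the first change that moves the number beyond the scatter, whereas the one earlier step cannot be read. Compound 3 is also the only compound here with a measured number rather than a limit, and the others stay at that limit: the limit of > 10000 nM in this assay, at which 2 of the 3 values shown sit.

Going by these compounds, the full size of the step stays open, as the value of compound 1 is only a limit. Also open, on these data alone, is whether chloro or methyl at this same position would act as fluoro does, and whether fluoro here would change the number for compound 2 as well.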